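This account rests on a few compounds, and the source may have more. Where it says the series, first, only, none or still open, it means among the compounds named here.

Measured compounds in a functional assay on K562 cells (Homo sapiens) for cytotoxicity, read by MTT assay; a higher number here means that more compound is needed for the effect, a lower number that less compound is needed:
Compound 1, `CCCCCCCCCCCCC/C=C/[C@@H](O)[C@H](CO)n1cc(CCC)nn1`, gives 13000 nM.
Compound 2, `CCCCCCCCCCCCC/C=C/[C@@H](O)[C@H](CO)n1cc(CCCCCCCCCCCCC)nn1`, gives > 50000 nM, which is a limit of the assay and not a number.
Compound 3, `CCCCCCCCCCCCC/C=C/[C@@H](O)[C@H](CO)n1cc(CCCCCCCCCCCCCCCCCCCCCCCC)nn1`, gives > 50000 nM, also a limit and not a number.

Compound 2 therefore stands only at a limit in this assay, a position it shares with one other compound, as the limit of > 50000 nM in this assay, at which 2 of the 3 values shown sit, records; no exact number for compound 2 is known. Compound 4, `CCCCCCCCCCCCC/C=C/[C@@H](O)[C@H](CO)n1cc(CCCCCC)nn1`, is not yet measured. Its difference from compound 2 is hydrogen in place of heptyl on a saturated chain carbon, six bonds along the chain from an aromatic carbon. Among the measured compounds shown here, one measured step bears on this change, and it runs in the opposite direction: an at least 3.8-fold higher number from compound 1 to compound 2 (0.58 log units; beyond the scatter), where lengthening the chain raised the number. The step that the two limits leave unreadable from compound 2 to compound 3 gives no usable size. Shortening the chain of compound 2 toward that of compound 1 is thus expected to bring the number down from the limit, though how far cannot be read from a limit. Compound 4 is estimated at 25000 nM in this assay, with a range from 9000 nM to 60000 nM. That estimate means an expected step of an at least 2.0-fold lower number from compound 2 to compound 4 (0.30 log units; that floor lies within the scatter).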

Compound 4, half-maximal effective concentration: 8200 nM
Beside the measured number, compound 4's estimate is 3.0-fold (0.48 log units) above it; measured number outside the range, below it.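

In this assay, among the compounds shown here, taking heptyl off the chain gives an at least 6.0-fold lower number from compound 2 to compound 4 (0.78 log units; beyond the scatter), so the chain of compound 2 can be cut back to reach a readable number, which the earlier compounds showed only from the opposite direction. Compound 2 itself stands at a limit and not at a number, so this step gives only a floor: the limit of > 50000 nM in this assay, at which 2 of the 4 values shown sit. At the short end, the chains give no readable difference, a 1.6-fold lower number from compound 1 to compound 4 (0.20 log units; within the scatter), so the rise toward the limit belongs to the stretch of chain that compound 2 carries beyond compound 4.

Where along that stretch the number starts to climb stays open, and the step to the longest chain cannot be read. Also open, from the compounds shown here alone, is how a chain of similar length ending in an amine or a carboxylic acid would behave in this assay.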